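A Fluorine Added to the Carboxyphenyl of Compound 1

This account rests on a few compounds, and the source may have more. Where it says the series, first, only, none or still open, it means among the compounds named here.

Compound 1 `O=C(O)c1ccc(C=C2CCN(C(=O)C(C3CCCCC3)C3CCCCC3)CC2)cc1`: 46%
Compound 2 `O=C(O)c1ccc(C=C2CCN(C(=O)CC(c3ccccc3)c3ccccc3)CC2)cc1`: 8%
Compound 3 `O=C(O)c1ccc(C=C2CCN(C(=O)C(c3ccccc3)c3ccccc3)CC2)cc1`: 26%

In an assay for inhibition of 3-oxo-5-alpha-steroid 4-dehydrogenase 1 (Homo sapiens), tested at 10 uM (a lower number here means less inhibition, a higher number more inhibition at the concentration tested (going by the name of the read-out)), compound 1 gives 46%, the highest of the three numbers. Compound 3 gives 26%, a gap beyond the scatter, and compound 2 gives 8%, the furthest below compound 1, also beyond the scatter. Compound 4 `O=C(O)c1ccc(C=C2CCN(C(=O)C(C3CCCCC3)C3CCCCC3)CC2)c(F)c1` keeps everything of compound 1 except one change: fluoro in place of hydrogen on an aromatic carbon. Within the data shown here, no pair of measured compounds shows what fluoro in place of hydrogen does here, so nothing in these three numbers points in either direction. The step of a number 1 percentage points lower from compound 1 to compound 4 (within the scatter) is therefore expected to stay within the scatter. Compound 4 is estimated at 45%, with a range from 25% to 65%.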

Compound 4, a percentage reported as inhibition, at one concentration (the size of the read-out at that concentration, not a potency): 12%
Compound 4: the middle estimate sits 33 percentage points above what was measured; measured number outside the range, below it.
By their numbers in this assay, from the lowest: compounds 2 and 4 (each within the scatter of the next); then compound 3; then compound 1.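

Fluoro in place of hydrogen, ortho to a large group and meta to a carboxy group, is not a silent change in this assay: it gives a number 34 percentage points lower from compound 1 to compound 4 (beyond the scatter), the first single-place step in this set. This position on the ring therefore matters, and the addition of a single fluorine is enough to change the read-out beyond the scatter. Nothing at hand accounts for the drop.

Going by these compounds, whether a chloro or methyl group on the same aromatic carbon would give a similar step remains open. So does whether 4-carboxy-2-fluorophenyl would cost as much in compound 3 as it does in compound 1.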